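Working notes: from compound 2 to compound 3

A few compounds are considered here, and "the series" means these few. Any claim that something is new, unique, unknown or untested is made for them only; others in the source may bear on it.

Measured in a physicochemical assay for lipophilicity, at pH 7.4; on this read-out lower numbers stand for lower lipophilicity and higher numbers for higher lipophilicity:
- compound 1 `Cc1cc(COc2cccc(Cl)c2)nc(-c2ccccn2)n1` – 3.7
- compound 2 `OC1CN(c2cc(COc3ccc(F)c(F)c3F)nc(-c3ccccn3)n2)C1` – 2.8

Of these two numbers, compound 2 is the lower at 2.8, while compound 1 reads 3.7, a gap beyond the usual scatter. The two differ in more than one place, so this gap cannot be tied to any single structural change.

The next compound to be read is compound 3 `Fc1ccc(OCc2cc(OCC3CCC3)nc(-c3ccccn3)n2)c(F)c1F`, which has no number yet. It differs from compound 2 as follows: cyclobutylmethoxy in place of 3-hydroxyazetidin-1-yl on an aromatic carbon. In words, cyclobutylmethoxy stands in place of 3-hydroxyazetidin-1-yl on an aromatic carbon, and the rest of the structure is unchanged.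

Within the data shown here, no measured pair shows a change of this kind, so the size of the step remains a judgement from the structures alone. A rise in this assay beyond the scatter is expected, starting from compound 2 at 2.8. The estimated step is a number 1.50 log units higher from compound 2 to compound 3 (beyond the scatter). Compound 3 is expected at 4.3, with an estimated range of 3.7 to 4.9.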

Compound 3, distribution coefficient: 4.5
Compound 3: middle estimate off by 0.20 log units, on the low side, within the range that was stated.
By their numbers in this assay, from the lowest: compound 2; then compound 1; then compound 3.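

In this assay, among these compounds, cyclobutylmethoxy in place of 3-hydroxyazetidin-1-yl on an aromatic carbon gives a number 1.70 log units higher from compound 2 to compound 3 (beyond the scatter), the first step that can be tied to a single place, and it shows that a change at this position alone can move the read-out by a large amount. The leaving group counts 1 hydrogen-bond donor and 2 hydrogen-bond acceptors, the entering group counts 0 hydrogen-bond donors and 1 hydrogen-bond acceptor, and both hold a four-membered non-aromatic ring and carry no net charge. Which of these differences carries the step cannot be told from one pair, and no separate measurement bears on its cause.

Open, as far as these compounds go, is how the read-out moves with a group of another kind on this carbon, such as an open-chain amine, a carboxylic acid or a longer alkoxy chain. Among the compounds shown here, also open is whether a step of this size holds when the rest of the structure differs, as this is the only pair that differs in one place.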